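A Third Fluorine on the Side Group: Compound 4

A few compounds are considered here, and "the series" means these few. Any claim that something is new, unique, unknown or untested is made for them only; others in the source may bear on it.

Compound 1 `Cc1cc(-c2noc([C@H](C)NC(=O)c3cc(C(F)(F)F)nn3C)n2)ccn1`: 14500 nM
Compound 2 `C[C@H](NC(=O)c1cc(C(F)(F)F)nn1C)c1nc(-c2ccnc(C3CC3)c2)no1`: 1140 nM
Compound 3 `C[C@H](NC(=O)c1cc(C(F)(F)F)nn1C)c1nc(-c2ccnc(C(F)F)c2)no1`: 1250 nM

All three were tested in an assay on T-REx-293 cells for inhibition of potassium channel subfamily T member 1 (Mus musculus), read by patch clamp; on this read-out lower numbers stand for stronger inhibition and higher numbers for weaker inhibition. Compound 3 holds the second highest number of the three: compound 2 lies nearest, with a 1.1-fold higher number from compound 2 to compound 3 (0.04 log units; within the scatter), while compound 1 is furthest, with a 12-fold lower number from compound 1 to compound 3 (1.06 log units; beyond the scatter). Compound 4 `C[C@H](NC(=O)c1cc(C(F)(F)F)nn1C)c1nc(-c2ccnc(C(F)(F)F)c2)no1` differs from compound 3 by fluoro in place of hydrogen on a saturated chain carbon bound to an aromatic carbon and two fluorine atoms. Within the data shown here, no measured step alters this same group, so the nearest guides are a 13-fold lower number from compound 1 to compound 2 (1.10 log units; beyond the scatter) and a 12-fold lower number from compound 1 to compound 3 (1.06 log units; beyond the scatter), both large moves away from methyl, while the step between the two replacement groups stays within the scatter. One more fluorine on an already fluorinated group is expected to give only a small step, if any, a 1.3-fold lower number from compound 3 to compound 4 (0.10 log units; within the scatter). Compound 4 is estimated in this assay at 1000 nM, with a range from 400 nM to 2500 nM.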

Compound 4, half-maximal inhibitory concentration: 622 nM
Compound 4: the middle estimate sits 1.6-fold (0.21 log units) above what was measured, within the range that was stated.
By their numbers in this assay, from the lowest: compounds 4, 2 and 3 (each within the scatter of the next); then compound 1.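

The step of a 2.0-fold lower number from compound 3 to compound 4 (0.30 log units; within the scatter) in this assay stays within the scatter, so going from difluoromethyl to trifluoromethyl brings no measurable shift at this position. Trifluoromethyl also cannot be told apart from cyclopropyl, with a 1.8-fold lower number from compound 2 to compound 4 (0.26 log units; within the scatter) inside the scatter as well. Against methyl it shows the same kind of large move, with a 23-fold lower number from compound 1 to compound 4 (1.37 log units; beyond the scatter) beyond the scatter, so compound 2, compound 3 and compound 4 sit together, apart from compound 1. From the compounds shown here alone, whether an amine or a methoxy group on this carbon would join them stays open. Nothing shown explains why methyl stands apart.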